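From chloro to dimethylamino in compound 3

This account rests on a few compounds, and the source may have more. Where it says the series, first, only, none or still open, it means among the compounds named here.

Compound 1 `CCCCCCC(CCO)n1cnc2c(N(C)C)ncnc21` gives > 50000 nM as a limit
Compound 2 `CCCCCCCCCCC(CCO)n1cnc2c(Cl)ncnc21` gives 4930 nM as a number

Among the measured compounds shown here, in a functional assay on HCT-116 cells (Homo sapiens) for antiproliferative activity, read by MTT assay, with a stated time of 48 h (a higher number here means a weaker inhibitor, a lower number a stronger inhibitor), compound 2 gives 4930 nM and holds the only number so far. Compound 1 reads > 50000 nM and that is a limit of the assay. Compound 3 `CCCCCCCCCCC(CCO)n1cnc2c(N(C)C)ncnc21` differs from compound 2 by dimethylamino in place of chloro on an aromatic carbon and awaits measurement. For the measured compounds named here, no measured step isolates this change. The expectation of a weakening beyond the scatter in this assay rests on compound 1, which also carries dimethylamino and reads > 50000 nM as a limit. The expected step is a 3.0-fold higher number from compound 2 to compound 3 (0.48 log units; beyond the scatter) by estimate. Compound 3 is estimated at 15000 nM with an expected range from 5000 nM to 45000 nM for the coming measurement.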

Compound 3, half-maximal inhibitory concentration: 5490 nM
Estimate against measurement, compound 3: 2.7-fold (0.44 log units) above, and the stated range covers the measured number.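

At this aromatic carbon, chloro and dimethylamino do not separate in this assay: the step is a 1.1-fold higher number from compound 2 to compound 3 (0.05 log units; within the scatter). With dimethylamino held in place, butyl in place of hydrogen on the saturated chain gives an at least 9.1-fold lower number from compound 1 to compound 3 (0.95 log units; beyond the scatter), so among the compounds carrying dimethylamino it is the chain that separates them. Compound 1 stands at a limit, not a number: the limit of > 50000 nM in this assay, at which 1 of the 3 values shown sits.

On these data alone, whether methoxy or a primary amine at this carbon would read like chloro and dimethylamino remains open. So does whether a longer chain would lower the number further.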